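Removing the ring methoxy from compound 1 in the benzotriazine di-N-oxide series

This account rests on a few compounds, and the source may have more. Where it says the series, first, only, none or still open, it means among the compounds named here.

Compound 1 `CCCOCNc1n[n+]([O-])c2cc(OC)ccc2[n+]1[O-]` gives 12000 nM in a functional assay on KB cells (Homo sapiens) for cytotoxicity, read by MTT assay, with a stated time of 72 h (a lower number here means a stronger inhibitor, a higher number a weaker inhibitor), the highest of the three numbers; compound 3 `COCNc1n[n+]([O-])c2ccccc2[n+]1[O-]` gives 9070 nM and compound 2 `[O-][n+]1nc(NCOCc2ccc(Cl)cc2)[n+]([O-])c2ccccc21` gives 8260 nM, both within the scatter of compound 1. Within the data shown here, the only single-point step measured, a 1.1-fold higher number from compound 2 to compound 3 (0.04 log units; within the scatter), concerns the side chain and does not touch the ring position changed here. Compound 4 `CCCOCNc1n[n+]([O-])c2ccccc2[n+]1[O-]` differs from compound 1 by hydrogen in place of methoxy on an aromatic carbon. Compound 3 already carries the unsubstituted ring and sits within the scatter of compound 1, so no step beyond the scatter is expected. Compound 4 is therefore estimated at 10000 nM, range 5000 nM to 20000 nM, meaning an expected step of a 1.2-fold lower number from compound 1 to compound 4 (0.08 log units; within the scatter).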

Compound 4, half-maximal inhibitory concentration: 10200 nM
Compound 4: the middle estimate sits 1.0-fold (0.01 log units) below what was measured, and the stated range covers the measured number.
By their numbers in this assay, from the lowest: compounds 2, 3, 4 and 1 (each within the scatter of the next).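

In this assay, among these compounds, hydrogen in place of methoxy on this aromatic carbon gives the first direct reading at this ring position (a 1.2-fold lower number from compound 1 to compound 4 (0.07 log units; within the scatter)), so the methoxy makes no difference beyond the scatter. With the ring unsubstituted, the side chain can now be read on two further steps (a 1.1-fold higher number from compound 3 to compound 4 (0.05 log units; within the scatter)) and (a 1.2-fold higher number from compound 2 to compound 4 (0.09 log units; within the scatter)), and hydrogen, ethyl and 4-chlorophenyl on the saturated chain carbon are not told apart.

As far as these compounds go, whether an amine or a carboxylic acid on this aromatic carbon would give a step beyond the scatter remains open. Nothing at hand accounts for the size of these steps.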